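Swapping cyano for methyl on a well-tolerated compound

The source may report more compounds than this note shows. Statements on the series, on what has been measured and on what is new or still open speak of the compounds shown alone.

Measured in an ADME assay on H9 cells (Homo sapiens) for cytotoxicity, read by XTT assay, with a stated time of 6 days; a higher number here means that more compound is tolerated, a lower number that less compound is tolerated:
- compound 1 `Cc1cc(C#N)cc(C)c1Oc1ccc([N+](=O)[O-])c(Nc2ccc(C#N)cc2)c1` gives > 65100 nM (a limit)
- compound 2 `Cc1cc(C#N)cc(C)c1Oc1cc(Nc2ccc(C#N)cc2)c([N+](=O)[O-])cc1[N+](=O)[O-]` gives > 58200 nM (a limit)
- compound 3 `Cc1cc(C#N)cc(C)c1Oc1ccc(N)c(Nc2ccc(C#N)cc2)c1` gives 49800 nM (a number)

As far as these compounds go, compound 1 gives only a limit (> 65100 nM) and no number, so its true value stays unknown. Only compound 3 has a real number here.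

The next candidate is compound 4 `Cc1cc(C)c(Oc2ccc([N+](=O)[O-])c(Nc3ccc(C#N)cc3)c2)c(C)c1`, which has not yet been measured. It keeps the shared core of compound 1 and changes one group (methyl in place of cyano on an aromatic carbon).

Two measured steps start from compound 1, and neither touches the cyano group that leaves here. Adding a second nitro gave a step that the two limits leave unreadable from compound 1 to compound 2 and so teaches little. Replacing nitro with amino gave an at least 1.3-fold lower number from compound 1 to compound 3 (0.11 log units; that floor lies within the scatter) and so shows no change that can be told from the scatter. Neither step gives a direct guide to the swap of cyano for methyl, so the expectation is weak: no step beyond the scatter, with a small drop possible. The expected step is an at least 1.3-fold lower number from compound 1 to compound 4 (0.11 log units; that floor lies within the scatter) and it remains an estimate.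

For compound 4 the estimated value is 50000 nM with an expected range from 15000 nM to 70000 nM in this assay and the assay may again report only a limit.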

Compound 4, half-maximal cytotoxic concentration: > 67000 nM
Compound 4 ended at the assay's limit (the forecaster's own chance of this, stated with the estimate: 55%); middle value at least 1.3-fold (0.12 log units) away from the limit.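

In this assay, compound 1 and compound 4 each give only a limit and not a number, so the step between them, methyl in place of cyano, cannot be read. The compounds shown leave open whether this swap changes the tolerated concentration at all, and in which direction.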